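The source may report more compounds than this note shows. Statements on the series, on what has been measured and on what is new or still open speak of the compounds shown alone.

Compound 1 `FC(F)(F)c1cccnc1N1CCC(NC(=S)Nc2cccnc2)CC1` in an assay on membranes from brain for binding affinity to Lysophosphatidylserine lipase ABHD12 (Mus musculus), read by fluorescence, with a stated time of 20 min (a lower number here means a stronger inhibitor, a higher number a weaker inhibitor), gives only a limit of the assay, > 5000 nM.
Compound 2 `FC(F)(F)Oc1ccc(Oc2ccnc(N3CCC(NC(=S)Nc4cccnc4)CC3)c2)cc1` gives in this assay 410 nM.
Compound 3 `N#Cc1c(Oc2ccc(OC(F)(F)F)cc2)ccnc1N1CCC(NC(=S)Nc2cccnc2)CC1` gives in this assay 180 nM.

Among the two measured numbers, compound 3 stands lowest; its nearest neighbour is compound 2, and the step of a 2.3-fold lower number from compound 2 to compound 3 (0.36 log units; beyond the scatter) lies beyond the scatter, brought about by cyano in place of hydrogen on an aromatic carbon. The value of compound 1 is a limit, (the limit of > 5000 nM in this assay, at which 1 of the 3 values shown sits), and stands apart from the other two.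

Compound 4 `FC(F)(F)Oc1ccc(Oc2ccnc(N3CCC(NC(=S)Nc4cccnc4)CC3)c2C(F)(F)F)cc1` has not yet been measured. It differs from compound 3 by trifluoromethyl in place of cyano on an aromatic carbon, in words trifluoromethyl in place of cyano on an aromatic carbon. Going by the values given here, the one measured step that touches this position, a 2.3-fold lower number from compound 2 to compound 3 (0.36 log units; beyond the scatter), shows that putting a cyano there instead of hydrogen gave a modest gain. Among the compounds with values here, no measured step compares trifluoromethyl with cyano at this carbon, so the expectation can rest only on compound 2 and compound 3 bracketing the plausible range.

Compound 4 is therefore expected to give about 260 nM in this assay, with a range from 90 nM to 800 nM, which means an expected step of a 1.4-fold higher number from compound 3 to compound 4 (0.16 log units; within the scatter) that is not beyond the scatter.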

Compound 4, half-maximal inhibitory concentration: 2800 nM
Estimate against measurement, compound 4: 11-fold (1.03 log units) below, outside the stated range (above it).
By their numbers in this assay, from the lowest: compound 3; then compound 2; then compound 4. At a limit, above all of these: compound 1.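

Going by these compounds alone, at the aromatic carbon ortho to the 4-(trifluoromethoxy)phenoxy group in this assay, the earlier compounds showed only a modest gain from cyano, a 2.3-fold lower number from compound 2 to compound 3 (0.36 log units; beyond the scatter), whereas the exchange of cyano for trifluoromethyl gives a 16-fold higher number from compound 3 to compound 4 (1.19 log units; beyond the scatter), a large loss. Trifluoromethyl also compares unfavourably with plain hydrogen at this carbon, with a 6.8-fold higher number from compound 2 to compound 4 (0.83 log units; beyond the scatter), so this position can move the number in either direction, and a substituent here does not in itself bring a gain. Compound 1 stands at a limit of the assay, and the step of an at least 1.7-fold lower number from compound 1 to compound 4 (0.25 log units; that floor lies within the scatter) is therefore only a floor: the limit of > 5000 nM in this assay, at which 1 of the 4 values shown sits.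

The compounds shown do not separate which difference between the two groups matters, as cyano brings a triple bond and a hydrogen-bond acceptor while trifluoromethyl brings neither and has more heavy atoms. From the compounds shown here alone, how a methyl group, a chlorine atom or a methoxy group at this same carbon would read in this assay remains open, and with it whether cyano is a special case or one of several groups that are accepted here.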